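A few compounds are considered here, and "the series" means these few. Any claim that something is new, unique, unknown or untested is made for them only; others in the source may bear on it.

Measured in a functional assay on HT-29 cells (Homo sapiens) for cytotoxicity, read by MTT assay, with a stated time of 72 h; on this read-out higher numbers stand for weaker inhibition and lower numbers for stronger inhibition:
- compound 1 `COC(=O)c1sc2c(C)cccc2c1Nc1cc(OC)c(OC)c(OC)c1`: 552 nM
- compound 2 `COC(=O)c1sc2cc(C)ccc2c1Nc1cc(OC)c(OC)c(OC)c1`: 1.9 nM

Compound 2 holds the lower of the two numbers, and the gap up to compound 1 lies well beyond the usual scatter. For the measured compounds named here, with only two values, this places compound 2 at the strong end of a very small set and says nothing wider about the series.

The next compound is compound 3 `COC(=O)c1sc2ccccc2c1Nc1cc(OC)c(OC)c(OC)c1`. It departs from compound 2 by hydrogen in place of methyl on an aromatic carbon. Going by the values given here, no measured pair isolates this change, so its size in this assay cannot be read from the data and remains an expectation. A step toward a higher number, beyond the scatter, is expected because compound 2 at 1.9 nM sits very low, leaving more room upward than downward. The expected change is a 21-fold higher number from compound 2 to compound 3 (1.32 log units; beyond the scatter). For compound 3 the estimated value is 40 nM, with an expected range of 6 nM to 300 nM.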

Compound 3, half-maximal inhibitory concentration: 299 nM
Beside the measured number, compound 3's estimate is 7.5-fold (0.87 log units) below it, and the stated range covers the measured number.
By their numbers in this assay, from the lowest: compound 2; then compounds 3 and 1 (each within the scatter of the next).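

In this assay the change at this carbon, meta to a fused ring and para to a fused ring, is a 160-fold higher number from compound 2 to compound 3 (2.20 log units; beyond the scatter) and counts as a large step, so the low number of compound 2 depends on this methyl. Hydrogen in place of methyl on the other carbon, the one holding the methyl of compound 1, gives a 1.8-fold lower number from compound 1 to compound 3 (0.27 log units; within the scatter) and stays within the scatter, so the same exchange has a very different size at the two carbons, and only the methyl of compound 2 separates clearly from the unsubstituted compound 3. Nothing measured here bears on why the two carbons differ so widely.

Going by these compounds, only methyl and hydrogen appear at this carbon, so it remains open whether a fluorine, a methoxy group or an ethyl chain there would keep a number near that of compound 2. On these data alone, it also remains open whether the large step would persist with a carboxylic acid or an amide in place of the methyl ester on the shared core.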